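A few compounds are considered here, and "the series" means these few. Any claim that something is new, unique, unknown or untested is made for them only; others in the source may bear on it.

Four compounds built on a shared core are compared here in an ADME assay on MT4 cells (Homo sapiens) for cytotoxicity, read by MTT assay, with a stated time of 4 days; a lower number here means that less compound is tolerated, a higher number that more compound is tolerated. Compound 1 `COc1cccc(-c2cc(=O)c3cc(NC(C)=O)ccc3o2)c1` carries a methoxy group on its pendant aromatic ring together with an acetamide on the core. In this assay compound 1 reaches only a limit of the assay, > 404000 nM, which is the limit of > 404000 nM in this assay, at which 1 of the 3 values shown sits. Compound 2 `CC(=O)Nc1ccc2oc(-c3cccc(F)c3)cc(=O)c2c1` differs from compound 1 by fluoro in place of methoxy on an aromatic carbon. In this assay compound 2 gives 240000 nM. The resulting step, an at least 1.6-fold lower number from compound 1 to compound 2 (0.22 log units; that floor lies within the scatter), is therefore bounded on one side only, since the starting point is a limit rather than a number.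

Compound 3 `COc1ccc(-c2cc(=O)c3cc(N)ccc3o2)cc1` bears a free amine on the core in place of the acetamide and a methoxy group; the difference between the cores of compound 1 and compound 3 is not broken down here. In this assay compound 3 gives 241000 nM, a number within the scatter of that of compound 2.

Compound 4 `Nc1ccc2oc(-c3ccc(F)cc3)cc(=O)c2c1` is not yet measured; it differs from compound 3 by fluoro in place of methoxy on an aromatic carbon. This is the same kind of change as that from compound 1 to compound 2, though there the place is meta to a large group and here para to a large group. The step expected, a 1.3-fold lower number from compound 3 to compound 4 (0.13 log units; within the scatter), rests on the measured step of an at least 1.6-fold lower number from compound 1 to compound 2 (0.22 log units; that floor lies within the scatter) and on compound 3 standing at 241000 nM. Compound 4 is thus expected to give 180000 nM, with a likely span from 90000 nM to 360000 nM.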

Compound 4, half-maximal cytotoxic concentration: 264000 nM
Beside the measured number, compound 4's estimate is 1.5-fold (0.17 log units) below it; measured number inside the range.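

In this assay, fluoro in place of methoxy on an aromatic carbon, here para to a large group, gives a 1.1-fold higher number from compound 3 to compound 4 (0.04 log units; within the scatter), so on the core with the free amine this change leaves a step that stays within the scatter. Set beside the same change on the acetamide core, this result gives no sign of a step that depends on the core, but it does not show that the two steps are equal, and the place of the change is also not the same in the two pairs: the same change on two cores in this assay, an at least 1.6-fold lower number (0.22 log units; that floor lies within the scatter) from compound 1 to compound 2 and a 1.1-fold higher number (0.04 log units; within the scatter) from compound 3 to compound 4; the limit leaves it open whether they differ The earlier step is bounded on one side only, since compound 1 stands at a limit of the assay and not at a number: the limit of > 404000 nM in this assay, at which 1 of the 4 values shown sits.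

The compounds shown leave open how a chloro, hydroxyl or amine group would read in that place in this assay, and whether fluoro and methoxy would compare in the same way if both stood at one place on one core. They also leave open whether a longer chain on the amide of the core, or a carboxylic acid on the pendant ring, would bring any step beyond the scatter.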